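From Methoxy to Ethyl: What to Expect for Compound 3

The compounds below may be only part of what the source reports. "The series", "measured", "known", "first", "only" and "open" are said of these compounds alone.

Among the measured compounds shown here, compound 1 `COc1ccccc1NC(=O)Nc1cccc(CNc2nccnc2Cl)c1` has the highest of the two numbers measured so far in a functional assay on HepG2 cells (Homo sapiens) for antiproliferative activity, read by MTT assay, with a stated time of 48 h (a higher number here means a weaker inhibitor, a lower number a stronger inhibitor), where compound 1 gives 13700 nM. Its nearest neighbour is compound 2 `Cc1ccc(NC(=O)Nc2cccc(CNc3nccnc3Cl)c2)c(C)c1`, which gives 9290 nM; that step, a 1.5-fold lower number from compound 1 to compound 2 (0.17 log units; within the scatter), came with 2,4-dimethylphenyl in place of 2-methoxyphenyl on an amide-type nitrogen. Compound 3 `CCc1ccccc1NC(=O)Nc1cccc(CNc2nccnc2Cl)c1` differs from compound 1 by ethyl in place of methoxy on an aromatic carbon. For the measured compounds named here, only the step from compound 1 to compound 2 bears on this change, and it stayed within the scatter, so no step beyond the scatter is expected: a 1.2-fold lower number from compound 1 to compound 3 (0.10 log units; within the scatter). For compound 3 the expected value is 11000 nM, within 5000 nM to 25000 nM.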

Compound 3, half-maximal inhibitory concentration: 7860 nM
The estimate for compound 3 lay 1.4-fold (0.15 log units) above the measured number; the measured number falls inside the stated range.
By their numbers in this assay, from the lowest: compounds 3, 2 and 1 (each within the scatter of the next).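

In this assay, ethyl in place of methoxy on this aromatic carbon, ortho to a large group, gives a 1.7-fold lower number from compound 1 to compound 3 (0.24 log units; within the scatter). The change removes the oxygen and the hydrogen-bond acceptor counted for methoxy, yet this position still shows no step beyond the scatter. Moving to 2-ethylphenyl from 2,4-dimethylphenyl gives a 1.2-fold lower number from compound 2 to compound 3 (0.07 log units; within the scatter), so compounds 1, 2 and 3 cannot be told apart here, and nothing available explains these readings. Still open, on these data alone, is whether an amine, a carboxylic acid or a longer chain such as butyl at this position would produce a step beyond the scatter.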